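Bromo for chloro on a series read only at limits

The source may hold more compounds than are shown below. What is called first, only, known or untested is meant among the compounds shown, and "the series" means these compounds.

Measured in a physicochemical assay for solubility, read by spectrophotometry (a higher number here means a more soluble compound, a lower number a less soluble compound), each reading a limit and not a number:
- compound 1 `O=C(Nc1ccc(Cl)c(Cl)c1)c1cc(Br)ccc1O`: < 100000 nM
- compound 2 `O=C(Oc1ccc(Br)cc1C(=O)Nc1ccc(Cl)c(Cl)c1)c1cnc(Cl)cn1`: < 100000 nM
- compound 3 `O=C(NCCCCl)Oc1ccc(Cl)cc1C(=O)Nc1ccc(Cl)c(Cl)c1`: < 50000 nM

Compound 3 stands only at its limit of < 50000 nM in this assay and has no numeric reading. The other two compounds also sit at a limit (the limit of < 100000 nM in this assay, at which 2 of the 3 values shown sit), while compound 3 alone sits at the limit of < 50000 nM in this assay, at which 1 of the 3 values shown sits. Compound 4 `O=C(NCCCCl)Oc1ccc(Br)cc1C(=O)Nc1ccc(Cl)c(Cl)c1` is the next case. It carries bromo in place of chloro on an aromatic carbon, para to a ((3-chloropropyl)carbamoyl)oxy group bromo in place of chloro on an aromatic carbon and otherwise matches compound 3.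

Among the compounds with values here, the one measured step is a step that the two limits leave unreadable from compound 1 to compound 2 and it is a different change at a different place, so it offers no size to carry over. Within the data shown here, no measured step covers this exchange, and no direction can be drawn from the data. The expected size is a step that the limit leaves unreadable from compound 3 to compound 4 and no step beyond the scatter is expected. For compound 4 the estimate is 30000 nM (expected range 8000 nM to 100000 nM) and a report as a limit is the likeliest outcome.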

Compound 4, solubility: < 50000 nM
Compound 4 was reported as a limit; the forecaster's own chance of this, stated with the estimate: 85%; the middle value lies beyond the limit too.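

In this assay compound 4 gives < 50000 nM, which is a limit and not a number. Within the data shown here, no step to compound 4 can be read from compound 1, compound 2 or compound 3. From the compounds shown here alone, whether bromo in place of chloro on this aromatic carbon shifts the reading at all, and in which direction, stays open.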